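Shorter selenocyanate ether chain: compound 4 against compound 3

The source may report more compounds than this note shows. Statements on the series, on what has been measured and on what is new or still open speak of the compounds shown alone.

Measured so far in a functional assay on MDA-MB-231 cells (Homo sapiens) for inhibition, read by MTT assay, with a stated time of 48 h; on this read-out lower numbers stand for stronger inhibition and higher numbers for weaker inhibition:
Compound 1, `COc1ccc(N(C)c2nc(C)nc3ccccc23)cc1OCCN`: 682 nM
Compound 2, `COc1ccc(N(C)c2nc(C)nc3ccccc23)cc1OCCCCCC[Se]C#N`: 3550 nM
Compound 3, `COc1ccc(N(C)c2nc(C)nc3ccccc23)cc1C(=O)OCCCC[Se]C#N`: 554 nM

Compound 3 has the lowest number of the three, but its gap to compound 1 is within the scatter, so only compound 2 stands clearly apart from it, a 6.4-fold lower number from compound 2 to compound 3 (0.81 log units; beyond the scatter).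

Compound 4, `COc1ccc(N(C)c2nc(C)nc3ccccc23)cc1OCCC[Se]C#N`, differs from compound 3 in one place: a group of 7 heavy atoms (4 carbon, 1 nitrogen, 1 oxygen, 1 selenium; no ring) in place of a group of 10 heavy atoms (6 carbon, 1 nitrogen, 2 oxygen, 1 selenium; no ring), on an aromatic carbon
The entering group is of the same kind as the chain of compound 2, joined through an oxygen on the aromatic ring, whereas compound 3 carries its chain through an ester.

Among the measured compounds shown here, two measured steps bear on this. The ether-linked selenocyanate chain of compound 2 gave a weaker number than the short amine ether of compound 1, a 5.2-fold higher number from compound 1 to compound 2 (0.72 log units; beyond the scatter), and moving from that ether chain to the ester chain of compound 3 brought the number back down, a 6.4-fold lower number from compound 2 to compound 3 (0.81 log units; beyond the scatter). Compound 4 returns to the ether link but with fewer chain carbons than compound 2, so a rise from compound 3 is expected, probably beyond the scatter but smaller than the full step seen for compound 2: a 2.7-fold higher number from compound 3 to compound 4 (0.43 log units; beyond the scatter). Compound 4 is therefore estimated at 1500 nM in this assay, with a range of 500 nM to 4500 nM.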

Compound 4, half-maximal inhibitory concentration: 815 nM
Compound 4: middle estimate off by 1.8-fold (0.26 log units), on the high side; the range from low to high includes it.
By their numbers in this assay, from the lowest: compounds 3, 1 and 4 (each within the scatter of the next); then compound 2.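

In this assay, the step from the ester chain to the group of 7 heavy atoms on this aromatic carbon stays within the scatter (a 1.5-fold higher number from compound 3 to compound 4 (0.17 log units; within the scatter)), so an ether link at this place does not by itself go with the high number of compound 2. Among the compounds shown here, the comparison of the two ether chains points to chain length instead, since the shorter selenocyanate chain gives a clear drop (a 4.4-fold lower number from compound 2 to compound 4 (0.64 log units; beyond the scatter)), the first step in this set in which only the chain length changes. The short selenocyanate ether also cannot be told apart from the amine ether (a 1.2-fold higher number from compound 1 to compound 4 (0.08 log units; within the scatter)), so at this chain length the selenocyanate end shows no gain or loss over the amine in this cell read-out.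

Nothing at hand explains why the longer ether chain stands apart from the other three compounds. Still open, as far as these compounds go, is how chain length behaves on the ester side, where a shorter or longer chain would test whether the link and the length act separately, and whether a carboxylic acid at this aromatic carbon would stay level with compound 3.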